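Cytotoxicity of benzothiazole bis-amides: a hexyl urea replaces an aminopropanoyl

The source may report more compounds than this note shows. Statements on the series, on what has been measured and on what is new or still open speak of the compounds shown alone.

Three compounds on a shared benzothiazole core have been examined in a functional assay on WI-38 VA13 cells (Homo sapiens) for cytotoxicity; on this read-out lower numbers stand for an effect already at smaller amounts and higher numbers for an effect only at larger amounts of compound. Compound 1 `O=C(Nc1ccc2nc(NC(=O)C3CCCCC3)sc2c1)c1ccc(Cl)cc1Cl` reaches only the limit of > 4 ug/mL in this assay, so for it no number is known. Compound 2 `CCC(C)(C)C(=O)Nc1ccc2nc(NC(=O)C3CCCCC3)sc2c1` gives 1 ug/mL, and the step of an at least 4.0-fold lower number from compound 1 to compound 2 (0.60 log units; beyond the scatter) shows that a 1,1-dimethylpropyl in place of 2,4-dichlorophenyl on a carbonyl carbon moves the number down. Compound 3 `NCCC(=O)Nc1nc2ccc(NC(=O)c3c(Cl)cccc3Cl)cc2s1` gives 5.3 ug/mL, the highest of the two numbers and well beyond the scatter from compound 2.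

Compound 4 `CCCCCCNC(=O)Nc1nc2ccc(NC(=O)c3c(Cl)cccc3Cl)cc2s1` is not yet measured. It differs from compound 3 by hexylamino in place of 2-aminoethyl on a carbonyl carbon. For the measured compounds named here, the only measured step, from compound 1 to compound 2, concerns the other amide of the core, and no measured step touches the side changed here, so it gives no direct guide. Going by the values given here, with compound 2 as the sole aliphatic-acyl example, a moderate downward movement is expected for compound 4, giving an estimated 2.5 ug/mL, with a range from 0.7 ug/mL to 10 ug/mL, which corresponds to an expected step of a 2.1-fold lower number from compound 3 to compound 4 (0.33 log units; beyond the scatter).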

Compound 4, half-maximal effective concentration: 0.29 ug/mL
The estimate for compound 4 lay 8.6-fold (0.94 log units) above the measured number; measured number below the stated range.
By their numbers in this assay, from the lowest: compound 4; then compound 2; then compound 3.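

In this assay, the carbonyl carbon whose other neighbour is an amide-type nitrogen proves to be a sensitive place: hexylamino in place of 2-aminoethyl gives an 18-fold lower number from compound 3 to compound 4 (1.26 log units; beyond the scatter), a large step. For the compounds shown here, the earlier measured step concerned the other amide of the core, so this is the first evidence that a change on this side can move the number strongly downward. Nothing shown gives a cause for this step.

The change replaces (2-aminoethyl)carbonyl with hexylcarbamoyl, altering the chain and the atom joining it to the carbonyl carbon together, and the compounds shown do not separate these two parts. A hexanoyl group, a butylcarbamoyl group or an octylcarbamoyl group at this place would show whether the chain, the added nitrogen or both carry the step.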